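A few compounds are considered here, and "the series" means these few. Any claim that something is new, unique, unknown or untested is made for them only; others in the source may bear on it.

Measured so far in a functional assay on PC-3 cells (Homo sapiens) for antiproliferative activity, read by MTT assay, with a stated time of 72 h; on this read-out higher numbers stand for weaker inhibition and lower numbers for stronger inhibition
compound 1 `CCN(CC)CCNC(=O)c1ccc(C(CC)(CC)c2ccc(OCC(O)C(C)(C)C)c(C)c2)n1CC` gives 2800 nM
compound 2 `CCN(CC)CCCNC(=O)c1ccc(C(CC)(CC)c2ccc(C#CC(O)(CC)CC)c(C)c2)n1CC` gives 8500 nM
compound 3 `C#CCCOC(=O)c1ccc(C(CC)(CC)c2ccc(C#CC(O)(CC)CC)c(C)c2)n1CC` gives > 50000 nM

For compound 3 the reading > 50000 nM is a limit of the assay and not a number. Compound 4 `CCn1c(C(=O)N[C@H](C(=O)O)C(C)C)ccc1C(CC)(CC)c1ccc(C#CC(O)(CC)CC)c(C)c1` has not yet been measured in this assay. It keeps the core of compound 3 and carries (1-carboxy-2-methylpropyl)amino in place of (but-3-yn-1-yl)oxy on a carbonyl carbon.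

Among the measured compounds shown here, one measured step bears on this change, at the same carbonyl carbon. It is an at least 5.8-fold higher number from compound 2 to compound 3 (0.76 log units; beyond the scatter), which lies beyond the scatter and brought in the same (but-3-yn-1-yl)oxy, there in place of (3-(diethylamino)propyl)amino. For the measured compounds named here, compound 1 differs from the others in more than one place and offers no step here. Going by the values given here, the measured step shows that the group on this carbonyl carbon can move the reading, but no measured compound carries the entering group, so its size does not carry over directly.

A lean toward a lower number rests on compound 2, with an amino group on this carbonyl carbon, at 8500 nM. The expected change is small, and the estimated step is an at least 1.6-fold lower number from compound 3 to compound 4 (0.22 log units; that floor lies within the scatter). Compound 4 is estimated at 30000 nM, with an expected range from 10000 nM to 80000 nM.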

Compound 4, half-maximal inhibitory concentration: 5000 nM
For compound 4 the middle estimate is 6.0-fold (0.78 log units) above the measured one, and the stated range ends above it.
By their numbers in this assay, from the lowest: compounds 1, 4 and 2 (each within the scatter of the next, the first and the last beyond it). At a limit, above all of these: compound 3.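

In this assay the (1-carboxy-2-methylpropyl)amino group on this carbonyl carbon brings a readable value where (but-3-yn-1-yl)oxy gave none, with an at least 10-fold lower number from compound 3 to compound 4 (1.00 log units; beyond the scatter) as the change on this swap. The step of a 1.7-fold lower number from compound 2 to compound 4 (0.23 log units; within the scatter) for 1-carboxy-2-methylpropyl in place of 3-(diethylamino)propyl on an amide-type nitrogen shows that a chain ending in a carboxylic acid and one ending in a diethylamino group read alike here, so a readable value at this position does not depend on the amine that compound 2 carries. Compound 3 stands at a limit of the assay and not at a number, so the first of these steps is only a floor: the limit of > 50000 nM in this assay, at which 1 of the 4 values shown sits.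

The compounds shown leave open how a plain unsubstituted amide or a methyl ester of the carboxylic acid in the entering group would read, and so whether the amide nitrogen or the chain on it matters more. They also leave open how the opposite configuration at the defined stereocentre, or a shorter chain ending in a carboxylic acid, would read on this carbonyl carbon.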